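Fluoro at the para position of compound 3's phenyl ring

This account rests on a few compounds, and the source may have more. Where it says the series, first, only, none or still open, it means among the compounds named here.

Measured so far:
- compound 1 `Cc1ccccc1-n1cc(-c2cccc(NS(=O)(=O)c3c[nH]c(=O)[nH]c3=O)c2)nn1`: 9570 nM
- compound 2 `O=c1[nH]cc(S(=O)(=O)Nc2cccc(-c3cn(-c4ccc(Cl)cc4)nn3)c2)c(=O)[nH]1`: 1960 nM
- compound 3 `O=c1[nH]cc(S(=O)(=O)Nc2ccc(-c3cn(-c4ccccc4)nn3)cc2)c(=O)[nH]1`: 18000 nM

All three were tested in a functional assay on HepG2 cells (Homo sapiens) for antiproliferative activity, read by MTT assay, with a stated time of 24 h; a higher number here means a weaker inhibitor, a lower number a stronger inhibitor. Compound 3 gives the highest number of the three: compound 1 lies a step away that is within the scatter, so the two cannot be ranked, while compound 2 sits well below, beyond the scatter. Compound 4 `O=c1[nH]cc(S(=O)(=O)Nc2ccc(-c3cn(-c4ccc(F)cc4)nn3)cc2)c(=O)[nH]1` has not yet been measured. It differs from compound 3 by a single change, (fluoro in place of hydrogen on an aromatic carbon), which cut one bond further out reads phenyl to 4-fluorophenyl.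

Within the data shown here, only one measured step touches this part of the molecule: a 4.9-fold lower number from compound 1 to compound 2 (0.69 log units; beyond the scatter). That step also put a halogen on the ring attached to the aromatic nitrogen, though it changed the ring in more than one way, so it is an imperfect guide. A smaller move in the same direction is expected, a 1.8-fold lower number from compound 3 to compound 4 (0.26 log units; within the scatter), possibly not beyond the scatter. Compound 4 is therefore estimated at 10000 nM, with a range from 4000 nM to 25000 nM.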

Compound 4, half-maximal inhibitory concentration: > 20000 nM
Compound 4 gave a limit, no number (the forecaster's own chance of this, stated with the estimate: 10%); at least 2.0-fold (0.30 log units) between middle value and limit.
By their numbers in this assay, from the lowest: compound 2; then compounds 1 and 3 (each within the scatter of the next). At a limit, above all of these: compound 4.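

Compound 4 gives a limit, not a number: the limit of > 20000 nM in this assay, at which 1 of the 4 values shown sits. Fluoro in place of hydrogen on the phenyl ring gives an at least 1.1-fold higher number from compound 3 to compound 4 (0.04 log units; that floor lies within the scatter), so this change brings no lower number, and how far apart the two really lie cannot be read. The earlier halogen step, a 4.9-fold lower number from compound 1 to compound 2 (0.69 log units; beyond the scatter), does not carry over to this core, which differs from the core of compound 1, although one pair on each core shows no general rule.

Still open, going by these compounds, is whether chloro, as carried by compound 2, would behave on the core of compound 3 as fluoro does here. Also open is what an amine or a carboxylic acid would do on this aromatic carbon, para to a large group, where only hydrogen and fluoro are shown on this core.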